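The source may report more compounds than this note shows. Statements on the series, on what has been measured and on what is new or still open speak of the compounds shown alone.

Measured so far:
compound 1, `C/C(=C\c1cc(-c2ccc(F)cc2)co1)C(N)=O` — in a functional assay on HO8910 cells (Homo sapiens) for cytotoxicity, read by CCK-8 assay, with a stated time of 24 h (on this read-out higher numbers stand for weaker inhibition and lower numbers for stronger inhibition), compound 1 gives > 50000 nM, which is a limit of the assay and not a number.
compound 2, `C/C(=C\c1cc(-c2ccccc2)cs1)C(N)=O` — in this assay compound 2 gives > 50000 nM, again a limit of the assay rather than a measured number.

Compound 2 therefore stands nowhere in particular on the numbers shown: its value is only a limit, and the other value shown is a limit as well. Going by the values given here, both sit at the same point, (the limit of > 50000 nM in this assay, at which 2 of the 2 values shown sit), so no ranking between compound 1 and compound 2 can be drawn, and no step between measured compounds is available.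

Compound 3, `C/C(=C\c1cc(-c2ccc(C)cc2)cs1)C(N)=O`, differs from compound 2 by methyl in place of hydrogen on an aromatic carbon. With both measured values at the limit, there is no basis for expecting a step in either direction beyond the scatter, and the most likely outcome in this assay is another limit. Compound 3 is expected to give about 60000 nM, with a range from 20000 nM to 200000 nM. The step that this estimate implies, a step that the limit leaves unreadable from compound 2 to compound 3, is expected to stay within the scatter, with a limit rather than a number the probable report.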

Compound 3, half-maximal inhibitory concentration: > 50000 nM
Compound 3 ended at the assay's limit (the forecaster's own chance of this, stated with the estimate: 85%); the middle value does not contradict the limit.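

No new step can be read from compound 2 to compound 3, since the values of both are limits of the assay and not numbers: the limit of > 50000 nM in this assay, at which 3 of the 3 values shown sit.

The compounds shown leave open what methyl in place of hydrogen on an aromatic carbon does in this assay, and whether any change to the shared core gives a readable value there.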